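The compounds below may be only part of what the source reports. "The series", "measured", "known", "first", "only" and "open" are said of these compounds alone.

Series notes. Compound 1 `COc1cc(O)c(C(=O)/C=C/c2ccc(OC)c(OCc3cn(-c4ccc(F)c(Cl)c4)nn3)c2)c(OC)c1` carries 3-chloro-4-fluorophenyl on an aromatic nitrogen. In an ADME assay on Huh-7 cells (Homo sapiens) for cytotoxicity, read by MTT assay, with a stated time of 72 h (a higher number here means that more compound is tolerated, a lower number that less compound is tolerated), compound 1 gives only a limit of the assay, > 100 ug/mL. Compound 2 `COc1cc(O)c(C(=O)/C=C/c2ccc(OC)c(OCc3cn(-c4ccc(Cl)cc4)nn3)c2)c(OC)c1` differs from compound 1 by 4-chlorophenyl in place of 3-chloro-4-fluorophenyl on an aromatic nitrogen. In this assay compound 2 likewise gives only a limit, > 100 ug/mL. The step that the two limits leave unreadable from compound 1 to compound 2 is thus not readable. Compound 3 `COc1cc(O)c(C(=O)/C=C/c2ccc(OCc3cn(-c4ccc(F)c(Cl)c4)nn3)c(OC)c2)c(OC)c1` has the same atoms as compound 1 joined differently; the difference between the two cores is not broken down here. In this assay compound 3 gives only a limit, > 100 ug/mL. Compound 4 `COc1cc(O)c(C(=O)/C=C/c2ccc(OCc3cn(-c4ccc(Cl)cc4)nn3)c(OC)c2)c(OC)c1` differs from compound 3 by 4-chlorophenyl in place of 3-chloro-4-fluorophenyl on an aromatic nitrogen, the same change as seen between the first two compounds. With every value resting at the limit of > 100 ug/mL in this assay, at which 3 of the 3 values shown sit, compound 4 is expected to stay at the limit, an expected step that the limit leaves unreadable from compound 3 to compound 4. The estimate for compound 4 is 150 ug/mL, between 80 ug/mL and 400 ug/mL.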

Compound 4, half-maximal cytotoxic concentration: > 100 ug/mL
Compound 4: a limit, no number; the forecaster's own chance of this, stated with the estimate: 85%; the middle value lies beyond the limit too.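

No step can be read from compound 3 to compound 4, since both give only a limit of the assay: the limit of > 100 ug/mL in this assay, at which 4 of the 4 values shown sit. The compounds shown leave open at what concentration any of them turns cytotoxic, and whether 4-chlorophenyl in place of 3-chloro-4-fluorophenyl shifts that concentration.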